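From 1-methylethenyl to 4-chlorophenyl on compound 1

The source may hold more compounds than are shown below. What is called first, only, known or untested is meant among the compounds shown, and "the series" means these compounds.

compound 1 (`C=C(C)CC1COC2(C=CC(=O)C=C2)N(c2ccccc2)C1=O`) gives 450 nM
compound 2 (`C=CCCC1COC2(C=CC(=O)C=C2)N(c2ccccc2)C1=O`) gives 730 nM
compound 3 (`O=C1C=CC2(C=C1)OCC(Cc1ccc(F)cc1)C(=O)N2c1ccccc1`) gives 400 nM

These three values come from a functional assay on BV-2 cells (Mus musculus), read by Griess assay, with a stated time of 24 h (on this read-out higher numbers stand for weaker inhibition and lower numbers for stronger inhibition), and they lie close together. Compound 1 stands within the usual scatter of both other compounds, so no ranking among the three can be read from these numbers.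

The next compound to be tested is compound 4 (`O=C1C=CC2(C=C1)OCC(Cc1ccc(Cl)cc1)C(=O)N2c1ccccc1`) and it keeps the core of compound 1. The change sits on a saturated chain carbon bound to a saturated ring carbon, and it is 4-chlorophenyl in place of 1-methylethenyl on a saturated chain carbon bound to a saturated ring carbon or, cut one bond further out, 2-methylprop-2-en-1-yl to 4-chlorobenzyl.

Three measured steps at this same place bear on it. The closest guide is the swap to 4-fluorophenyl, where a 1.1-fold lower number from compound 1 to compound 3 (0.05 log units; within the scatter) stayed within the scatter. The other two, a 1.6-fold higher number from compound 1 to compound 2 (0.21 log units; within the scatter) and a 1.8-fold lower number from compound 2 to compound 3 (0.26 log units; within the scatter) also stayed within it. Changes at this place have so far moved the number very little, although only three compounds show this.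

The step expected in this assay is a 1.1-fold lower number from compound 1 to compound 4 (0.05 log units; within the scatter) and so nothing beyond the scatter, in either direction. In this assay the estimate for compound 4 is 400 nM with 200 nM to 800 nM as the expected span.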

Compound 4, half-maximal inhibitory concentration: 540 nM
Compound 4: middle estimate off by 1.4-fold (0.13 log units), on the low side; measured number inside the range.
By their numbers in this assay, from the lowest: compounds 3, 1, 4 and 2 (each within the scatter of the next).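

In this assay, the 4-chlorobenzyl group fits among the groups already seen at this place: a 1.2-fold higher number from compound 1 to compound 4 (0.08 log units; within the scatter) and a 1.4-fold lower number from compound 2 to compound 4 (0.13 log units; within the scatter) both leave the number within the scatter. This extends the flat picture from the two chains and the fluorinated group to a second halogen-bearing benzyl group, so all four compounds remain too close to rank. Going by these compounds alone, compounds 3 and 4 also form the first pair here that differs only in the halogen, and chloro in place of fluoro on an aromatic carbon gives a 1.4-fold higher number from compound 3 to compound 4 (0.13 log units; within the scatter), again too small a step to separate the two halogens. No supporting measurement is available to explain why these different groups give such similar numbers.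

As far as these compounds go, the groups at this place are all either hydrocarbon chains or halogen-bearing benzyl groups, so the effect of a group carrying an amine or a carboxylic acid remains open. From the compounds shown here alone, it also remains open whether a plain benzyl group or a longer chain would stay within the same narrow band or finally move the number beyond the scatter.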